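Quinoline and benzothiazole thiosemicarbazones: aryl swap at the amide nitrogen

The source may report more compounds than this note shows. Statements on the series, on what has been measured and on what is new or still open speak of the compounds shown alone.

Measured compounds:
compound 1 `COc1cccc(NC(=S)N/N=C/c2ccc3ccccc3n2)c1`: 79400 nM
compound 2 `CN(C)C(=S)N/N=C/c1nc2ccccc2s1`: 830 nM
compound 3 `NC(=S)N/N=C/c1nc2ccccc2s1`: > 100000 nM

In a functional assay on SGC-7901 cells (Homo sapiens) for antiproliferative activity, read by sulforhodamine B assay, with a stated time of 72 h (a lower number here means a stronger inhibitor, a higher number a weaker inhibitor), compound 1 gives 79400 nM, the highest of the two numbers recorded; its nearest neighbour is compound 2 with 830 nM. Compound 3 reaches only a limit of the assay, > 100000 nM, so no number is known for it (the limit of > 100000 nM in this assay, at which 1 of the 3 values shown sits).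

Going by the values given here, the one step measured so far, an at least 120-fold higher number from compound 2 to compound 3 (2.08 log units; beyond the scatter), concerns the thiocarbonyl carbon and not the amide-type nitrogen, so it does not bear on the change to compound 4 `Fc1ccc(NC(=S)N/N=C/c2ccc3ccccc3n2)cc1`, which differs from compound 1 as follows: 4-fluorophenyl in place of 3-methoxyphenyl on an amide-type nitrogen. Among the compounds with values here, no measured pair shows the effect of exchanging one aryl group for another at this position, so no step beyond the scatter is expected in this assay.

Compound 4 is therefore estimated at 80000 nM, with a range from 25000 nM to 250000 nM. The expected step is a 1.0-fold higher number from compound 1 to compound 4 (0.00 log units; within the scatter).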

Compound 4, half-maximal inhibitory concentration: 32300 nM
For compound 4 the middle estimate is 2.5-fold (0.39 log units) above the measured one, within the range that was stated.
By their numbers in this assay, from the lowest: compound 2; then compound 4; then compound 1. At a limit, above all of these: compound 3.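

In this assay, the exchange of one aryl group for another on the amide-type nitrogen gives a 2.5-fold lower number from compound 1 to compound 4 (0.39 log units; beyond the scatter), so the aryl group at this position does affect the read-out, though the step is modest. The pair changes the substituent and its place on the phenyl ring together, so the step cannot be assigned to either change alone. The evidence at hand gives no cause for this step.

An unsubstituted phenyl group at this nitrogen would give a reference point for both compound 1 and compound 4, and a phenyl group carrying a carboxylic acid or an amine would test a wider range of substituents. From the compounds shown here alone, whether the step carries over to the core of compound 2 also remains open.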